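This account rests on a few compounds, and the source may have more. Where it says the series, first, only, none or still open, it means among the compounds named here.

Measured so far, in a functional assay on M21 cells (Homo sapiens) for antiproliferative activity, read by sulforhodamine B assay, with a stated time of 48 h; on this read-out lower numbers stand for stronger inhibition and higher numbers for weaker inhibition:

compound 1 `O=C1NCCN1c1ccc(S(=O)(=O)Nc2ccc(C3CCCCC3)cc2)cc1`: > 1000 nM, which is a limit of the assay and not a number.
compound 2 `O=C1NCCN1c1ccc(S(=O)(=O)Nc2ccc(Cl)cc2)cc1`: 90 nM.
compound 3 `Cc1ccc(NS(=O)(=O)c2ccc(N3CCNC3=O)cc2)cc1`: 260 nM.

Compound 3 therefore stands highest of the two numbers in this assay; compound 2 is the nearest, with a 2.9-fold higher number from compound 2 to compound 3 (0.46 log units; beyond the scatter). Compound 1 sits at the limit of > 1000 nM in this assay, at which 1 of the 3 values shown sits.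

Compound 4 `CCCCc1ccc(NS(=O)(=O)c2ccc(N3CCNC3=O)cc2)cc1` differs from compound 3 by propyl in place of hydrogen on a saturated chain carbon bound to an aromatic carbon. For the measured compounds named here, the steps that bear on this are the ones that change the size of the group on the aromatic carbon: an at least 3.8-fold lower number from compound 1 to compound 3 (0.58 log units; beyond the scatter) and an at least 11-fold lower number from compound 1 to compound 2 (1.04 log units; beyond the scatter), both running from the largest group to a smaller one and both giving lower numbers. Growing the group again, from methyl to butyl, runs the other way, toward compound 1, whose value in this assay is a limit. A step of at least modest size toward a higher number is therefore expected for compound 4, with a real chance that this assay again returns only a limit; the expected step is a 2.7-fold higher number from compound 3 to compound 4 (0.43 log units; beyond the scatter). The estimate for compound 4 in this assay is 700 nM, expected to lie between 250 nM and 2500 nM.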

Compound 4, half-maximal inhibitory concentration: 450 nM
Compound 4: middle estimate off by 1.6-fold (0.19 log units), on the high side; measured number inside the range.
By their numbers in this assay, from the lowest: compound 2; then compounds 3 and 4 (each within the scatter of the next). At a limit, above all of these: compound 1.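

In this assay, methyl and butyl on the aromatic carbon are not told apart, so lengthening the chain this far leaves the read-out within the scatter: a 1.7-fold higher number from compound 3 to compound 4 (0.24 log units; within the scatter). Butyl nevertheless stays separated from both neighbours in the series, with chloro in its place giving a 5.0-fold higher number from compound 2 to compound 4 (0.70 log units; beyond the scatter) and the exchange of cyclohexyl for butyl giving an at least 2.2-fold lower number from compound 1 to compound 4 (0.34 log units; beyond the scatter). The second of these comparisons rests on a limit of the assay and not a number, held by compound 1: the limit of > 1000 nM in this assay, at which 1 of the 4 values shown sits.

Going by these compounds, whether a longer chain such as hexyl, or a small ring such as cyclopropyl, would read like butyl or like cyclohexyl remains open. On these data alone, it is equally open whether other small groups in this place, such as fluoro or methoxy, would read like chloro or like methyl.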